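The source may hold more compounds than are shown below. What is called first, only, known or untested is meant among the compounds shown, and "the series" means these compounds.

Measured compounds, with minimum effective dose in a functional assay on the whole organism (blood, strain Wistar-Okamoto) with Rattus norvegicus as the target, with a stated time of 5 days; a lower number here means that less compound is needed, a higher number that more compound is needed for the effect:

Compound 1 `CCC/N=C(\NC#N)Nc1cccnc1`: 20 mg/kg
Compound 2 `CCCCC/N=C(\NC#N)Nc1cccnc1`: 20 mg/kg
Compound 3 `N#CN/C(=N\C1CC1)Nc1cccnc1`: 20 mg/kg

Compound 3 stands level with compounds 1 and 2 in this assay ; no value separates from another beyond the scatter. All three share the same core, and the group on the double-bonded nitrogen is the only part that varies.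

Compound 4 `CC(C)C(C)(C)/N=C(\NC#N)Nc1cccnc1` is not yet measured. Its change from compound 3 is 1,1,2-trimethylpropyl in place of cyclopropyl on a double-bonded nitrogen.

Among the measured compounds shown here, the steps that bear on it are those that also exchange the group on the double-bonded nitrogen : no change at the digits printed from compound 1 to compound 3 (within the scatter) and no change at the digits printed from compound 2 to compound 3 (within the scatter). The chain-lengthening step no change at the digits printed from compound 1 to compound 2 (within the scatter) points the same way. Every alkyl or cycloalkyl group tried at this position has given the same reading, so for compound 4 the expectation is a step of no change at the digits printed from compound 3 to compound 4 (within the scatter) that stays within the scatter, with no direction favoured.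

Compound 4 is therefore estimated at 20 mg/kg in this assay, expected to lie between 10 mg/kg and 40 mg/kg.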

Compound 4, minimum effective dose: 1 mg/kg
Compound 4: middle estimate off by 20-fold (1.30 log units), on the high side; measured number outside the range, below it.
By their numbers in this assay, from the lowest: compound 4; then compounds 1, 2 and 3 (each within the scatter of the next).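

In this assay the group on a double-bonded nitrogen is not silent: 1,1,2-trimethylpropyl gives a 20-fold lower number from compound 3 to compound 4 (1.30 log units; beyond the scatter), a 20-fold lower number from compound 2 to compound 4 (1.30 log units; beyond the scatter) and a 20-fold lower number from compound 1 to compound 4 (1.30 log units; beyond the scatter). Among the compounds shown here, the reading at this position therefore does not hold for every alkyl group, and the longer chain alone gave no such step, with no change at the digits printed from compound 1 to compound 2 (within the scatter). Nothing available gives a reason for the step.

Which part of 1,1,2-trimethylpropyl carries the step stays open, since no other branched group, such as tert-butyl or 1,1-dimethylpropyl, stands on this nitrogen in the compounds shown. Also open, from the compounds shown here alone, is whether a larger ring such as cyclohexyl on this nitrogen would read with compound 4 or with compounds 1, 2 and 3.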